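The source may report more compounds than this note shows. Statements on the series, on what has been measured and on what is new or still open speak of the compounds shown alone.

Series notes. Compound 1 `CCCCCC(=O)Nc1cccc(S(=O)(=O)Oc2ccccc2C(C)C)c1` gives 11000 nM in a functional assay on HT-1080 cells (Homo sapiens) for antiproliferative activity, read by sulforhodamine B assay, with a stated time of 48 h; on this read-out lower numbers stand for stronger inhibition and higher numbers for weaker inhibition. Compound 2 `CC(C)C(=O)Nc1cccc(S(=O)(=O)Oc2ccccc2C(C)C)c1` gives 16000 nM in this assay; the change isopropyl in place of pentyl on a carbonyl carbon made a 1.5-fold higher number from compound 1 to compound 2 (0.16 log units; within the scatter). Going by the values given here, compound 3 `CCCCCC(=O)Nc1ccc(S(=O)(=O)Oc2ccccc2C(C)C)cc1` gives 6300 nM in this assay; the difference between the core of compound 3 and the core of compound 1 is not broken down here, and the two values show only that compound 3 sits below compound 2 while lying within the scatter of compound 1. Compound 4 `CC(C)C(=O)Nc1ccc(S(=O)(=O)Oc2ccccc2C(C)C)cc1` is not yet measured; it differs from compound 3 by isopropyl in place of pentyl on a carbonyl carbon, the same change as from compound 1 to compound 2. For compound 4 in this assay a step of a 1.5-fold higher number from compound 3 to compound 4 (0.18 log units; within the scatter) is expected, resting on the value that compound 3 gives, 6300 nM, and on the earlier step of a 1.5-fold higher number from compound 1 to compound 2 (0.16 log units; within the scatter). Compound 4 is therefore estimated at 9500 nM, with a range from 5000 nM to 18000 nM.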

Compound 4, half-maximal inhibitory concentration: 4900 nM
Estimate against measurement, compound 4: 1.9-fold (0.29 log units) above; the whole stated range lies above it.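

In this assay isopropyl in place of pentyl on the carbonyl carbon gives a 1.3-fold lower number from compound 3 to compound 4 (0.11 log units; within the scatter) and so stays small on this core as well. Across the two cores, the size of the change does not differ by more than the scatter: the same change on two cores in this assay, a 1.5-fold higher number (0.16 log units; within the scatter) from compound 1 to compound 2 and a 1.3-fold lower number (0.11 log units; within the scatter) from compound 3 to compound 4, 1.9-fold (0.27 log units) apart, within the scatter of two such steps. This shows that the change made no step beyond the scatter on either core, but it gives no readable direction for the change and does not show that the result holds on any other core in the series.

Still open, as far as these compounds go, is whether a longer chain than pentyl or a ring-bearing acyl group such as benzoyl would move the number beyond the scatter. The same question stands for a carboxylic acid or an amine at the end of the acyl chain.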